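One group exchange among three closely matched compounds

The compounds below may be only part of what the source reports. "The series", "measured", "known", "first", "only" and "open" are said of these compounds alone.

In a functional assay on VCaP cells (Homo sapiens) for antiproliferative activity, read by propidium iodide staining, with a stated time of 96 h (on this read-out higher numbers stand for weaker inhibition and lower numbers for stronger inhibition), compound 1 `CC(O)(CSc1ccc(C(F)(F)F)cc1)C(=O)Nc1ccc(S(F)(F)(F)(F)F)cc1` gives 24800 nM in the test, compound 2 `CC(O)(CSc1ccccc1C(F)(F)F)C(=O)Nc1ccc(S(F)(F)(F)(F)F)cc1` gives 21000 nM in the same test, and compound 3 `CC(O)(CSc1ccc(S(F)(F)(F)(F)F)cc1)C(=O)Nc1cccc(S(F)(F)(F)(F)F)c1` gives 24100 nM there. Compound 3 thus stands level with the other two: all three numbers lie within the scatter of one another, so repeat measurements could not be expected to separate them.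

Compound 4 `CC(O)(CSc1ccc(OC(F)(F)F)cc1)C(=O)Nc1cccc(S(F)(F)(F)(F)F)c1` differs from compound 3 in one place. The change is a group of 5 heavy atoms (1 carbon, 1 oxygen, 3 fluorine; no ring) in place of a group of 6 heavy atoms (5 fluorine, 1 sulfur; no ring), on an aromatic carbon and the group that enters is trifluoromethoxy, on an aromatic carbon para to a large group. Among the measured compounds shown here, no measured pair shows this exchange directly. For the measured compounds named here, the only measured step between compounds differing in one place is a 1.2-fold lower number from compound 1 to compound 2 (0.07 log units; within the scatter) for 2-(trifluoromethyl)phenyl in place of 4-(trifluoromethyl)phenyl on a sulfur, and it stays within the scatter. That is a different change, so it is only a loose guide, but it shows no movement in these numbers. The step expected in this assay is therefore none beyond the scatter, an estimated 1.1-fold lower number from compound 3 to compound 4 (0.04 log units; within the scatter) in this small set. The estimate for compound 4 is 22000 nM as the expected middle, with an expected range from 10000 nM to 40000 nM in repeat measurements.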

Compound 4, half-maximal inhibitory concentration: 28500 nM
The estimate for compound 4 lay 1.3-fold (0.11 log units) below the measured number; measured number inside the range.
By their numbers in this assay, from the lowest: compounds 2, 3, 1 and 4 (each within the scatter of the next).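

In this assay, the exchange gives a 1.2-fold higher number from compound 3 to compound 4 (0.07 log units; within the scatter), so replacing the group of 5 fluorine atoms and 1 sulfur atom with trifluoromethoxy, on an aromatic carbon para to a large group, does not separate the two compounds. Among the compounds shown here, the only earlier step moved a trifluoromethyl group to another position, whereas this one puts a different group in place, and it too stays within the usual scatter of repeat measurements. The entering group carries 1 hydrogen-bond acceptor where the leaving group carries 0, yet this difference comes with no measurable separation, and no measured evidence is available to explain the result.

As far as these compounds go, the two groups compared here are both fluorine-bearing and have no ring, so it remains open whether a group of another kind at this carbon, such as an amine, a carboxylic acid or a longer alkyl chain, would move the number beyond the scatter. From the compounds shown here alone, it is also open whether the same exchange would read alike with changes made elsewhere on the shared core.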